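Chloro in Place of Fluoro: What to Expect of Compound 4

The compounds below may be only part of what the source reports. "The series", "measured", "known", "first", "only" and "open" are said of these compounds alone.

The measured compounds, each with its result in a functional assay on HCT-116 cells (Homo sapiens) for inhibition, read by CCK-8 assay, with a stated time of 72 h, tested at 2 uM; on this read-out higher numbers stand for more inhibition of growth at the one concentration tested and lower numbers for less inhibition of growth:
compound 1, `Nc1ccccc1NC(=O)/C=C/c1ccc(CSc2ccc(Cl)cc2)cc1`: 5.62%
compound 2, `Nc1ccccc1NC(=O)/C=C/c1ccc(CSc2ccc(F)cc2)cc1`: 14.1%
compound 3, `Nc1ccccc1NC(=O)c1ccc(CSc2ccc(F)cc2)cc1`: 13.5%

For the measured compounds named here, all three numbers sit close together, and no compound can be called the most or least active on this read-out. Compound 2 and compound 1 share a core and differ in one place: chloro in place of fluoro on an aromatic carbon. The step of a number 8.5 percentage points lower from compound 2 to compound 1 (within the scatter) is modest and remains within the scatter, so the data show no clear effect of this change. Compound 3 carries a different core from compound 2; the difference between the two cores is not broken down here, and the two values lie close to each other.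

Compound 4, `Nc1ccccc1NC(=O)c1ccc(CSc2ccc(Cl)cc2)cc1`, has not been measured. It stands to compound 3 as compound 1 stands to compound 2: chloro in place of fluoro on an aromatic carbon. The place of the change reads the same in both pairs, so this is the same change made on a second core. Because the earlier step of a number 8.5 percentage points lower from compound 2 to compound 1 (within the scatter) was small, the step from compound 3 to compound 4 is expected to be small as well, estimated at a number 6.5 percentage points lower from compound 3 to compound 4 (within the scatter). Compound 4 is therefore expected to give about 7% in this assay , with a range from -3% to 17% reflecting the scatter of such measurements.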

Compound 4, percent growth inhibition at one concentration: 17.5%
The estimate for compound 4 lay 10.5 percentage points below the measured number; measured number above the stated range.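

In this assay, chloro in place of fluoro on the second core gives a step of a number 4 percentage points higher from compound 3 to compound 4 (within the scatter). Set beside the step on the first core, this step shows no difference between the cores that rises above the usual variation: the same change on two cores in this assay, a number 8.5 percentage points lower (within the scatter) from compound 2 to compound 1 and a number 4 percentage points higher (within the scatter) from compound 3 to compound 4, 12.5 percentage points apart, within the scatter of two such steps The change therefore has no clear effect on either core, and nothing here indicates that the shared core alters its outcome, but the data do not show that the change is truly without effect or that the two cores respond to it alike, only that steps of this size cannot be told apart on this read-out at the single concentration tested.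

The compounds shown carry only 4-fluorophenyl and 4-chlorophenyl groups on the sulfur, and they leave open whether a methoxy group, a trifluoromethyl group, an amine or a carboxylic acid at the same place on that ring would produce a step beyond the scatter. They also leave open what a longer chain in place of the link that joins the sulfur to the rest of the molecule would do on either core.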